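Ortho substituent swap on the sulfonyl aryl ring

The source may report more compounds than this note shows. Statements on the series, on what has been measured and on what is new or still open speak of the compounds shown alone.

Measured compounds in an ADME assay on HEK293 cells (Homo sapiens) for cytotoxicity, read by resazurin assay, with a stated time of 48 h; a higher number here means that more compound is tolerated, a lower number that less compound is tolerated:
compound 1 `O=S(=O)(Nc1ccc2oc(-c3ccccc3)nc2c1)c1ccccc1O` gives 33000 nM
compound 2 `O=S(=O)(Nc1ccc2oc(-c3ccccc3)nc2c1)c1cccc(F)c1` gives 68000 nM
compound 3 `O=S(=O)(Nc1ccc2oc(-c3ccccc3)nc2c1)c1ccccc1F` gives 72000 nM

Compound 3 has the highest number of the three, but its gap to compound 2 is within the scatter, a 1.1-fold higher number from compound 2 to compound 3 (0.02 log units; within the scatter), so the two cannot be ordered. Against compound 1 the step is beyond the scatter, a 2.2-fold higher number from compound 1 to compound 3 (0.34 log units; beyond the scatter), and so is the step of a 2.1-fold higher number from compound 1 to compound 2 (0.31 log units; beyond the scatter).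

Compound 4 `COc1ccccc1S(=O)(=O)Nc1ccc2oc(-c3ccccc3)nc2c1` is to be measured in this assay. Its difference from compound 3: methoxy in place of fluoro on an aromatic carbon

The step that bears on it is the one at the same place on the ring, a 2.2-fold higher number from compound 1 to compound 3 (0.34 log units; beyond the scatter), where a hydroxy gave way to a fluoro. Among the compounds with values here, no measured step covers a methoxy, so the size of the present change has no direct precedent here. Given that hydroxy and fluoro at this place differed only modestly, and that fluoro at either place gave about the same number, a step within or just beyond the scatter is expected, more likely downward than upward. The expected step is a 1.4-fold lower number from compound 3 to compound 4 (0.16 log units; within the scatter). Compound 4 is expected to give 50000 nM, with a range from 25000 nM to 100000 nM.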

Compound 4, half-maximal cytotoxic concentration: 41000 nM
The estimate for compound 4 lay 1.2-fold (0.09 log units) above the measured number; low and high end bracket the measured number.
By their numbers in this assay, from the lowest: compounds 1, 4, 2 and 3 (each within the scatter of the next, the first and the last beyond it).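

In (this assay), methoxy on this aromatic carbon, ortho to a large group, cannot be separated from either of the other two substituents at this place: both steps (a 1.8-fold lower number from compound 3 to compound 4 (0.24 log units; within the scatter)) and (a 1.2-fold higher number from compound 1 to compound 4 (0.09 log units; within the scatter)) lie within the scatter, even though the step from hydroxy to fluoro at the same place lies beyond it. Placing a methyl on the hydroxy oxygen therefore gives no readable step, and the comparison with the 3-fluorophenyl compound (a 1.7-fold lower number from compound 2 to compound 4 (0.22 log units; within the scatter)) is equally unresolved, so compound 4 cannot be ordered against any of the other three. No measurement at hand speaks to the origin of these numbers.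

Still open, on these data alone, is whether an amine, a carboxylic acid or a longer alkoxy chain at this place would give a step beyond the scatter from the methoxy compound, and whether 3-methoxyphenyl would match 2-methoxyphenyl as closely as the two fluorophenyl compounds match each other. As far as these compounds go, the phenyl group on the shared core is the same in all four compounds, so the effect of any change there remains unknown.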